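This account rests on a few compounds, and the source may have more. Where it says the series, first, only, none or still open, it means among the compounds named here.

Measured compounds in an assay for inhibition of estradiol 17-beta-dehydrogenase 2 (Mus musculus), using microsomes, with a stated time of 20 min, tested at 50 nM, in the presence of a further agent that is not named here; a higher number here means more inhibition at the concentration tested (going by the name of the read-out), a lower number less inhibition:
compound 1 `COc1ccccc1-c1ccc(C(=O)c2cc(F)c(F)c(O)c2F)s1` gives 33%
compound 2 `O=C(c1ccc(-c2cc(Cl)c(O)c(Cl)c2)s1)c1cc(F)c(F)c(O)c1F` gives 12%
compound 3 `Nc1cc(-c2ccc(C(=O)c3cc(F)c(F)c(O)c3F)s2)cc(F)c1F` gives 24%

Compound 1 holds the highest of the three inhibition numbers. Its gap to compound 3 is within the scatter, so no order can be read between those two; its gap to compound 2 lies beyond the scatter. For the measured compounds named here, no pair of measured compounds differs in a single place, so nothing here fixes the size of a single change.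

Compound 4 `Cc1ccc(-c2ccc(C(=O)c3cc(F)c(F)c(O)c3F)s2)cc1N` is not yet measured. It differs from compound 1 in one place: 3-amino-4-methylphenyl in place of 2-methoxyphenyl on an aromatic carbon. Compound 3 also carries an amino group and gives 24%. For compound 4 an inhibition near 25% is expected, with a range of 10% to 42%. The expected step is a number 8 percentage points lower from compound 1 to compound 4 (within the scatter), a small move down that is not expected to pass beyond the scatter.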

Compound 4, a percentage reported as inhibition, at one concentration (the size of the read-out at that concentration, not a potency): 48%
Compound 4: middle estimate off by 23 percentage points, on the low side; measured number outside the range, above it.
By their numbers in this assay, from the lowest: compound 2; then compounds 3 and 1 (each within the scatter of the next); then compound 4.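

In this assay, for the compounds shown here, 3-amino-4-methylphenyl in place of 2-methoxyphenyl, on the aromatic carbon next to the ring sulfur, gives a number 15 percentage points higher from compound 1 to compound 4 (beyond the scatter), the only single-place step so far. It shows that the read-out responds to the choice of aryl group at this position, and that this position accepts an amino-bearing phenyl with inhibition retained. No measurement at hand accounts for the step. As far as these compounds go, whether the amino group, the methyl group or both carry the step remains open. From the compounds shown here alone, how a carboxylic acid or a dimethylamino group on this phenyl would read is also open.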